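Replacing the methylcarbamoyl of compound 3 with a six-membered diaza ring

The source may report more compounds than this note shows. Statements on the series, on what has been measured and on what is new or still open speak of the compounds shown alone.

The three measured compounds share one core carrying a chain ending in a phenyl ring, and differ only in the group on the aromatic carbon of the five-membered ring. Compound 1 `COc1ccnc(-c2cnc(C(=O)CCCCCCc3ccccc3)o2)c1` gives 0.8 nM in an assay (Rattus norvegicus) for inhibition of Fatty-acid amide hydrolase 1 (Homo sapiens); on this read-out lower numbers stand for stronger inhibition and higher numbers for weaker inhibition. Compound 2 `NC(=O)c1ccc(-c2cnc(C(=O)CCCCCCc3ccccc3)o2)nc1` gives 1.2 nM in this assay. Compound 3 `CNC(=O)c1cnc(C(=O)CCCCCCc2ccccc2)o1` gives 7 nM in this assay, the highest of the three numbers. The step of a 1.5-fold higher number from compound 1 to compound 2 (0.18 log units; within the scatter) lies within the scatter, while an 8.8-fold higher number from compound 1 to compound 3 (0.94 log units; beyond the scatter) and a 5.8-fold higher number from compound 2 to compound 3 (0.77 log units; beyond the scatter) are both modest but real.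

Compound 4 `O=C(CCCCCCc1ccccc1)c1ncc(-c2cc(=O)[nH]c(=O)[nH]2)o1` has not been measured. It differs from compound 3 in one place: a group of 8 heavy atoms (4 carbon, 2 nitrogen, 2 oxygen; one six-membered aromatic ring with 2 hetero atoms) in place of a group of 4 heavy atoms (2 carbon, 1 nitrogen, 1 oxygen; no ring), on an aromatic carbon. The two informative steps both show that a six-membered aromatic ring with hetero atoms on this carbon gives lower numbers than methylcarbamoyl does, by an 8.8-fold higher number from compound 1 to compound 3 (0.94 log units; beyond the scatter) and a 5.8-fold higher number from compound 2 to compound 3 (0.77 log units; beyond the scatter) read in reverse. The group entering compound 4 is again a six-membered aromatic ring with two hetero atoms, though with two hydrogen-bond donors and two acceptors rather than the pyridine groups of compound 1 and compound 2. On that basis compound 4 is expected to show a lower number than compound 3, a step of about a 3.5-fold lower number from compound 3 to compound 4 (0.54 log units; beyond the scatter) in this assay. Compound 4 is therefore estimated at 2 nM, with a range of 0.5 nM to 8 nM.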

Compound 4, inhibition constant: 12 nM
For compound 4 the middle estimate is 6.0-fold (0.78 log units) below the measured one; the measured number lies above the stated range.
By their numbers in this assay, from the lowest: compounds 1 and 2 (each within the scatter of the next); then compounds 3 and 4 (each within the scatter of the next).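

On this aromatic carbon, a six-membered aromatic ring is not enough on its own to give the low numbers of the pyridine compounds: the entering ring leaves the result within the scatter of methylcarbamoyl, with a 1.7-fold higher number from compound 3 to compound 4 (0.23 log units; within the scatter) in this assay. The pyridine groups now stand apart from this ring as well as from methylcarbamoyl, with a 10-fold higher number from compound 2 to compound 4 (1.00 log units; beyond the scatter) and a 15-fold higher number from compound 1 to compound 4 (1.18 log units; beyond the scatter), so what the ring carries and which atoms it holds matter here, not only its presence and size. The compounds shown come with no further measurement that could account for this separation.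

From the compounds shown here alone, it remains open which part of the entering group sets it apart from 5-carbamoylpyridin-2-yl and 4-methoxypyridin-2-yl, since its ring nitrogens and ring carbonyl groups change together. A plain pyrimidine ring without the carbonyl groups, or an unsubstituted pyridin-2-yl ring, on the same carbon would show whether the result follows the ring atoms or the groups attached to them.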